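Oxadiazole to Thiadiazole: an Expected Step

The source may hold more compounds than are shown below. What is called first, only, known or untested is meant among the compounds shown, and "the series" means these compounds.

Going by the values given here, compound 2 `Cc1nnc(SCc2coc3ccccc3c2=O)o1` gives 790 nM in a functional assay on SW480 cells (Homo sapiens) for cytotoxicity, read by MTT assay, with a stated time of 72 h (on this read-out lower numbers stand for stronger inhibition and higher numbers for weaker inhibition), the lower of the two numbers measured so far. Among the compounds with values here, its only measured neighbour, compound 1 `Cc1nnc(SCc2coc3ccc(Cl)cc3c2=O)o1`, gives 3500 nM in this assay, and the step of a 4.4-fold lower number from compound 1 to compound 2 (0.65 log units; beyond the scatter) came from hydrogen in place of chloro on an aromatic carbon. Compound 3 `Cc1nnc(SCc2coc3ccccc3c2=O)s1` has not yet been measured. It differs from compound 2 by 5-methyl-1,3,4-thiadiazol-2-yl in place of 5-methyl-1,3,4-oxadiazol-2-yl on a sulfur. Within the data shown here, no measured step bears on this change: the single step recorded in this assay concerns the halogen on the aromatic carbon, and nothing has been measured about the five-membered aromatic ring with 3 hetero atoms attached to the sulfur. What is counted in that change stays the same on both sides, so in this assay no step beyond the scatter is expected from compound 2 to compound 3. On that footing compound 3 is expected to give 650 nM in this assay, with a range of 250 nM to 1800 nM. This corresponds to an expected step of a 1.2-fold lower number from compound 2 to compound 3 (0.08 log units; within the scatter).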

Compound 3, half-maximal inhibitory concentration: 1000 nM
Beside the measured number, compound 3's estimate is 1.5-fold (0.19 log units) below it, within the range that was stated.
By their numbers in this assay, from the lowest: compounds 2 and 3 (each within the scatter of the next); then compound 1.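

In this assay, putting 5-methyl-1,3,4-thiadiazol-2-yl in place of 5-methyl-1,3,4-oxadiazol-2-yl on the sulfur gives a 1.3-fold higher number from compound 2 to compound 3 (0.10 log units; within the scatter), so this change of one ring atom, oxygen to sulfur, leaves no difference that can be read at this position. Going by these compounds alone, this is the first measurement to bear on the five-membered ring attached to the sulfur, since the earlier step, a 4.4-fold lower number from compound 1 to compound 2 (0.65 log units; beyond the scatter), concerned only the chloro on an aromatic carbon; that step remains the only one here beyond the scatter. The data given offer nothing that would explain the outcome of the ring exchange.

The compounds shown leave open whether the position would accept something further from these two rings, such as an amine, a carboxylic acid or a phenyl ring on the sulfur, or a longer chain in place of the methyl. They also leave open whether a chloro on the aromatic carbon of compound 3 would bring the same step as it does between compound 1 and compound 2.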